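Terminal ring variation on a shared core

The source may report more compounds than this note shows. Statements on the series, on what has been measured and on what is new or still open speak of the compounds shown alone.

Compound 1 `COc1cc(CC(O)c2ccc(-c3ccc(C#N)cc3)cc2)c([N+](=O)[O-])cc1OC` and compound 2 `COc1cc(CC(O)c2ccc(-c3ccc(F)cc3)cc2)c([N+](=O)[O-])cc1OC` share one core and differ only in the group on the terminal aromatic ring. In an ADME assay on HeLa Rh cells (Homo sapiens) for cytotoxicity, read by microscopy (on this read-out lower numbers stand for higher toxicity in this test and higher numbers for lower toxicity in this test), compound 1 gives 4700 nM and compound 2 gives 4500 nM; the step of a 1.0-fold lower number from compound 1 to compound 2 (0.02 log units; within the scatter). On these two numbers compound 2 sits with compound 1 inside the scatter, nothing separating them. Compound 3 `COc1cc(CC(O)c2ccc(-c3cccnc3)cc2)c([N+](=O)[O-])cc1OC` carries pyridin-3-yl in place of 4-fluorophenyl on an aromatic carbon. Going by the values given here, only the step from compound 1 to compound 2 bears on this change, and it was flat, so for compound 3 no shift beyond the scatter is expected in this assay, as no change at the digits printed from compound 2 to compound 3 (within the scatter). Compound 3 is therefore estimated at 4500 nM, range 2200 nM to 9000 nM.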

Compound 3, half-maximal cytotoxic concentration: > 263000 nM
Compound 3 was reported as a limit; the forecaster's own chance of this, stated with the estimate: 5%; middle value at least 58-fold (1.76 log units) from the limit.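

On an aromatic carbon para to a large group, the terminal ring is not the silent place that the earlier pair suggested: in this assay pyridin-3-yl in place of 4-fluorophenyl gives an at least 58-fold higher number from compound 2 to compound 3 (1.76 log units; beyond the scatter) and pyridin-3-yl in place of 4-cyanophenyl gives an at least 55-fold higher number from compound 1 to compound 3 (1.74 log units; beyond the scatter), whereas the change between the two substituted phenyl groups stayed within the scatter. The number for compound 3 is a limit, so both steps are minimum sizes: the limit of > 263000 nM in this assay, at which 1 of the 3 values shown sits.

Going by these compounds, whether the shift belongs to the ring nitrogen or to the loss of the substituted phenyl stays open. Pyridin-4-yl, unsubstituted phenyl or a phenyl bearing an amine would bear on this.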